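Compound 2 and its 4-methylphenyl counterpart

The source may hold more compounds than are shown below. What is called first, only, known or untested is meant among the compounds shown, and "the series" means these compounds.

In a functional assay on MCF7 cells (Homo sapiens) for cytotoxicity, read by sulforhodamine B assay, with a stated time of 48 h (a higher number here means a weaker inhibitor, a lower number a stronger inhibitor), compound 2 `Nc1nccc(-c2cnc3ccccc3c2)n1` gives > 50000 nM, which is a limit and not a number. Compound 1 `FC(F)(F)c1ccc(Nc2nccc(-c3cnc4ccccc4c3)n2)cc1` gives > 50000 nM, also a limit. Compound 2 therefore stands at the limit of > 50000 nM in this assay, at which 2 of the 3 values shown sit. Compound 3 `Cc1nc2ccccn2c1-c1ccnc(Nc2ccc(C=O)s2)n1` gives a measured value of 4270 nM.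

Compound 4 `Cc1ccc(Nc2nccc(-c3cnc4ccccc4c3)n2)cc1` carries 4-methylphenyl in place of hydrogen on a nitrogen on an aromatic ring. Among the measured compounds shown here, no measured step in this assay covers this change. The expectation rests on compound 1, which shares the core and gives > 50000 nM, a limit. Only a small shift towards stronger inhibition, or none beyond the scatter, is expected, as the estimated step of an at least 1.2-fold lower number from compound 2 to compound 4 (0.09 log units; that floor lies within the scatter). For compound 4 the estimate is 40000 nM, with an expected range of 12000 nM to 80000 nM.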

Compound 4, half-maximal inhibitory concentration: 50000 nM
Beside the measured number, compound 4's estimate is 1.3-fold (0.10 log units) below it; measured number inside the range.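

In this assay compound 4 gives 50000 nM, a number and not a limit, so the shared core now has one readable value, with 4-methylphenyl on the nitrogen, and this change gives a number no higher from compound 2 to compound 4 (the limit leaves the size open). Methyl in place of trifluoromethyl on an aromatic carbon gives a number no higher from compound 1 to compound 4 (the limit leaves the size open). The size of neither step can be read. Compound 2 remains a limit: the limit of > 50000 nM in this assay, at which 2 of the 4 values shown sit.

Still open, on these data alone, is how the number on this core responds to a carboxylic acid or an amine in place of methyl on the phenyl ring.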